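A few compounds are considered here, and "the series" means these few. Any claim that something is new, unique, unknown or untested is made for them only; others in the source may bear on it.

Three compounds have so far been measured in a functional assay on B16-F0 cells (Mus musculus) for inhibition, read by CCK-8 assay, with a stated time of 48 h (on this read-out higher numbers stand for weaker inhibition and lower numbers for stronger inhibition), as follows:
- Compound 1 `COc1cc(-c2ccnc3cc(-c4ccc(C)cc4)nn23)cc(OC)c1OC` gives 21 nM
- Compound 2 `COc1cc(-c2ccnc3cc(-c4ccc(C)c(C)c4)nn23)cc(OC)c1OC` gives 391 nM
- Compound 3 `C=Cc1ccc(-c2cc3nccc(-c4cc(OC)c(OC)c(OC)c4)n3n2)cc1` gives 788 nM

Compound 3 stands at the upper end of these numbers, level with compound 2 once the scatter is allowed for (a 2.0-fold higher number from compound 2 to compound 3 (0.30 log units; within the scatter)). Compound 1 lies far from both.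

Compound 4 `COc1ccc(-c2cc3nccc(-c4cc(OC)c(OC)c(OC)c4)n3n2)cc1` differs from compound 3 by methoxy in place of vinyl on an aromatic carbon, para to a large group (methoxy in place of vinyl on an aromatic carbon).

Going by the values given here, two measured steps bear on this change. The one at the same place is large (a 38-fold higher number from compound 1 to compound 3 (1.57 log units; beyond the scatter)). The other, a methyl in place of hydrogen on an aromatic carbon, is also large (a 19-fold higher number from compound 1 to compound 2 (1.27 log units; beyond the scatter)). Together they show that the number can move far with small changes on this ring. Among the compounds with values here, no measured compound carries methoxy, so neither step gives the size directly. With compound 1 at 21 nM as the only sign that much lower numbers are reachable, a moderately lower number is expected, well short of the full distance to compound 1.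

The estimated step is (a 3.2-fold lower number from compound 3 to compound 4 (0.50 log units; beyond the scatter)). The value expected for compound 4 is 250 nM within an estimated range of 50 nM to 1000 nM as its ends.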

Compound 4, half-maximal inhibitory concentration: 1410 nM
Beside the measured number, compound 4's estimate is 5.6-fold (0.75 log units) below it, and the stated range ends below it.
By their numbers in this assay, from the lowest: compound 1; then compounds 2, 3 and 4 (each within the scatter of the next, the first and the last beyond it).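

In this assay, exchanging the vinyl group for a methoxy group, para to a large group, gives no change that can be told from the scatter (a 1.8-fold higher number from compound 3 to compound 4 (0.25 log units; within the scatter)), so the two groups sit level here, and 4-methoxyphenyl brings no recovery towards the low number of compound 1. The methyl of compound 1 now stands apart from a second group at this place (a 67-fold higher number from compound 1 to compound 4 (1.83 log units; beyond the scatter)), and the 4-methoxyphenyl compound also lies modestly, though beyond the scatter, above the 3,4-dimethylphenyl compound (a 3.6-fold higher number from compound 2 to compound 4 (0.56 log units; beyond the scatter)), so that each of the three departures from 4-methylphenyl shown gives a much higher number than compound 1, with none going against this. Nothing available here accounts for why methyl differs so sharply from vinyl and methoxy at this place.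

The compounds shown leave open whether a chlorine atom or an ethyl group at this place would stay close to compound 1, at 21 nM, or fall in with compound 3 and compound 4. They also leave open how an amine or a carboxylic acid on this ring would read out.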